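This account rests on a few compounds, and the source may have more. Where it says the series, first, only, none or still open, it means among the compounds named here.

Measured compounds:
Compound 1, `Cc1ccc(Sc2cccc(N)c2C#N)cc1` — > 200000 nM
Compound 2, `N#Cc1ccc(Sc2cccc(N)c2C#N)cc1` — > 200000 nM
Compound 3, `Cc1cccc([S+]([O-])c2cccc(N)c2C#N)c1` — > 200000 nM

In a functional assay on MT4 cells (Homo sapiens) for cytotoxicity (on this read-out lower numbers stand for stronger inhibition and higher numbers for weaker inhibition), compound 1 gives only a limit of the assay, > 200000 nM, and not a number. Compound 2 likewise gives only a limit of the assay in this assay, namely > 200000 nM. Compound 3 too stands at a limit of the assay in this assay, > 200000 nM. All three values sit at the same limit, as the limit of > 200000 nM in this assay, at which 3 of the 3 values shown sit, records, so no reading among them can be placed in order.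

The change from compound 1 to compound 2 is cyano in place of methyl on an aromatic carbon. Its step in this assay, a step that the two limits leave unreadable from compound 1 to compound 2, is not readable, since both ends are limits.

Compound 4, `N#Cc1cccc([S+]([O-])c2cccc(N)c2C#N)c1`, is yet to be measured. It arises from compound 3 by cyano in place of methyl on an aromatic carbon. This is the same kind of change as that from compound 1 to compound 2, but not the same: in compound 2 the group sits para to a large group, whereas in compound 4 it sits meta to a large group. How the core of compound 3 differs from the core of compound 1 is not broken down here.

For the measured compounds named here, because the limit of > 200000 nM in this assay, at which 3 of the 3 values shown sit, shows every value so far at the limit, the step from compound 3 to compound 4 is expected to be unreadable as well, a step that the limit leaves unreadable from compound 3 to compound 4. Compound 4 is therefore expected to give about 300000 nM in this assay, most likely again only as a limit, between 150000 nM and 1000000 nM.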

Compound 4, half-maximal inhibitory concentration: > 200000 nM
Compound 4: a limit, no number; the forecaster's own chance of this, stated with the estimate: 85%; the middle value does not contradict the limit.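

In this assay compound 4 gives only a limit of the assay, > 200000 nM, and not a number. Compound 3 also stands at a limit, so the step between compound 3 and compound 4, cyano in place of methyl on an aromatic carbon, cannot be read. The compounds shown leave open how they rank and whether this change alters the read-out at all: the limit of > 200000 nM in this assay, at which 4 of the 4 values shown sit.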